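Halogen swap on the aryl ring: bromo to iodo

The source may report more compounds than this note shows. Statements on the series, on what has been measured and on what is new or still open speak of the compounds shown alone.

Measured so far:
- compound 1, `COC(=O)C1=C(C)N=C(C)/C(=C(\O)OC)C1c1cccc(Br)c1`: 1.29 nM
- compound 2, `COC(=O)C1=C(C)N=C(C)/C(=C(/O)OC)C1c1cccc(Cl)c1`: 15.9 nM

In a functional assay (muscle tissue) with Cavia porcellus as the target (on this read-out higher numbers stand for an effect only at larger amounts of compound and lower numbers for an effect already at smaller amounts), compound 1 gives 1.29 nM, the lower of the two numbers recorded. Compound 2, which carries a 3-chlorophenyl group in place of the 3-bromophenyl group, gives 15.9 nM in this assay, a higher number that lies beyond the usual scatter. Compound 1 therefore stands as the compound with the smaller effective concentration among the two measured.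

The step now considered leads to compound 3, `COC(=O)C1=C(C)N=C(C)/C(=C(\O)OC)C1c1cccc(I)c1`, which has not yet been tested in this assay. The change is iodo in place of bromo on an aromatic carbon; it sits on an aromatic carbon of a six-membered aromatic ring of carbon only, meta to a large group. Within the data shown here, no measured pair shows this exact change, so its effect cannot be read from the data. With one heavy atom exchanged for another of the same kind, the step from compound 1 to compound 3 is expected to be small, a 1.6-fold higher number from compound 1 to compound 3 (0.19 log units; within the scatter), with no clear direction beyond the scatter. Compound 3 is therefore estimated at 2 nM in this assay, within a range from 0.5 nM to 8 nM.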

Compound 3, half-maximal effective concentration: 41.7 nM
Compound 3: middle estimate off by 21-fold (1.32 log units), on the low side, outside the stated range (above it).
By their numbers in this assay, from the lowest: compound 1; then compound 2; then compound 3.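

In this assay, iodo in place of bromo on this aromatic carbon gives a 32-fold higher number from compound 1 to compound 3 (1.51 log units; beyond the scatter) and so shows that the position, meta to a large group, does not treat these two halogens alike. The exchange involves a single heavy atom on each side, with no ring, hydrogen-bond donor, hydrogen-bond acceptor or net charge entering or leaving, yet that alone moves the number well beyond the scatter. Nothing available here accounts for the size of this step.

The compounds shown leave open how a group other than a halogen, such as methyl, methoxy, nitrile or an amine, would read on this same aromatic carbon. They also leave open whether iodo in place of bromo would give a step of similar size elsewhere on the ring.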